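The source may report more compounds than this note shows. Statements on the series, on what has been measured and on what is new or still open speak of the compounds shown alone.

Working notes on the series. In a functional assay on MGC-803 cells (Homo sapiens) for inhibition, read by MTT assay, with a stated time of 48 h (on this read-out lower numbers stand for stronger inhibition and higher numbers for weaker inhibition), compound 3 `COc1ccc(CN(C(=O)CBr)c2cc(OC)c(OC)c(OC)c2)cc1O` gives 140 nM, the lowest number among the three measured; compound 1 `C=C(C)C(=O)N(Cc1ccc(OC)c(O)c1)c1cc(OC)c(OC)c(OC)c1` gives 390 nM and compound 2 `COc1ccc(CN(C(=O)CCCCCl)c2cc(OC)c(OC)c(OC)c2)cc1O` gives 540 nM, both beyond the scatter from compound 3. The next compound, compound 4 `COc1ccc(CN(C(=O)C(C)C)c2cc(OC)c(OC)c(OC)c2)cc1O`, differs from compound 3 by isopropyl in place of bromomethyl on a carbonyl carbon. For the measured compounds named here, two measured steps bear on this, both ending at the bromomethyl compound: a 2.8-fold lower number from compound 1 to compound 3 (0.44 log units; beyond the scatter) and a 3.9-fold lower number from compound 2 to compound 3 (0.59 log units; beyond the scatter), each a modest lowering on arrival at bromomethyl. Removing the bromomethyl in favour of isopropyl is therefore expected to undo that gain, a modest rise in this assay of about a 3.2-fold higher number from compound 3 to compound 4 (0.51 log units; beyond the scatter). Compound 4 is estimated at 450 nM, with a likely range of 200 nM to 1000 nM.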

Compound 4, half-maximal inhibitory concentration: 210 nM
Compound 4: middle estimate off by 2.1-fold (0.33 log units), on the high side; low and high end bracket the measured number.
By their numbers in this assay, from the lowest: compounds 3, 4, 1 and 2 (each within the scatter of the next, the first and the last beyond it).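

In this assay, bromine is not required for a low number at this place on the carbonyl carbon: isopropyl and bromomethyl cannot be told apart (a 1.5-fold higher number from compound 3 to compound 4 (0.18 log units; within the scatter)). Isopropyl also stands clear of 4-chlorobutyl (a 2.6-fold lower number from compound 2 to compound 4 (0.41 log units; beyond the scatter)), yet cannot be separated from 1-methylethenyl (a 1.9-fold lower number from compound 1 to compound 4 (0.27 log units; within the scatter)). No supporting measurement bears on why these steps take this form.

Still open, from the compounds shown here alone, is whether an amine or a carboxylic acid on this carbonyl carbon would keep the number near that of isopropyl. Also open, going by these compounds, is how a longer unbranched alkyl chain without chlorine would compare with 4-chlorobutyl.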